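Cyano on the Aryl Ring and Tolerated Concentration

The source may hold more compounds than are shown below. What is called first, only, known or untested is meant among the compounds shown, and "the series" means these compounds.

The measured compounds and their values:
compound 1, `Cc1ccccc1-c1ccnc(NCc2cc(-c3ccccc3)[nH]n2)c1`, gives > 10000 nM
compound 2, `Cc1ccccc1-c1ccnc(NCc2cc(-c3ccccc3)[nH]n2)n1`, gives > 10000 nM
compound 3, `Cc1cc(C#N)ccc1-c1ccnc(NCc2cc(-c3ccccc3)[nH]n2)c1`, gives > 10000 nM

All three values come from an ADME assay on CEM174 cells (Homo sapiens) for cytotoxicity; a higher number here means that more compound is tolerated, a lower number that less compound is tolerated. The value of compound 1 is a limit of the assay and not a number. The value of compound 2 is likewise a limit of the assay. The value of compound 3 is also a limit of the assay.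

Compound 1 and compound 3 differ in one place: cyano in place of hydrogen on an aromatic carbon. The step that the two limits leave unreadable from compound 1 to compound 3 cannot be read because the limit of > 10000 nM in this assay, at which 3 of the 3 values shown sit, holds both of them, so the size of this step is not known from the measured pair.

Compound 2 differs from compound 1 in its core; the difference between the two cores is not broken down here.

Compound 4, `Cc1cc(C#N)ccc1-c1ccnc(NCc2cc(-c3ccccc3)[nH]n2)n1`, has not yet been measured in this assay. From compound 2 it differs by the same change seen above: cyano in place of hydrogen on an aromatic carbon. Both measured examples sit at the limit, so the step from compound 2 to compound 4 is expected to be small, a step that the limit leaves unreadable from compound 2 to compound 4. Compound 4 is therefore expected to give about 15000 nM, most likely between 7000 nM and 40000 nM, and quite possibly only another limit.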

Compound 4, half-maximal cytotoxic concentration: > 10000 nM
Compound 4: only a limit was reported; the forecaster's own chance of this, stated with the estimate: 85%; the middle value is on the limit's open side.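

The step between compound 2 and compound 4 cannot be read, because each of the two compounds gives a limit of this assay and not a number: the limit of > 10000 nM in this assay, at which 4 of the 4 values shown sit.

The compounds shown leave open what concentration of any of them harms the cells, and whether cyano in place of hydrogen, or the difference in core, changes that concentration at all.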